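This account rests on a few compounds, and the source may have more. Where it says the series, first, only, none or still open, it means among the compounds named here.

The measured compounds, each in an ADME assay on Raji cells (Homo sapiens) for cytotoxicity, read by CellTiter-Glo and resazurin assay, with a stated time of 72 h; a higher number here means that more compound is needed for the effect, a lower number that less compound is needed:

Compound 1, `CC(=O)c1cccc(-c2ccc(C(=O)N(Cc3cccc(OCCCCCC(=O)O)c3)C(C)C)cc2)c1`, gives a limit of the assay rather than a number: > 26000 nM.
Compound 2, `CC(C)N(Cc1cccc(OCCCCCC(=O)O)c1)C(=O)c1ccc(-c2cccc(S(C)(=O)=O)c2)cc1`, likewise gives a limit: > 26000 nM.
Compound 3, `CCOC(=O)CCCCCOc1cccc(CN(C(=O)c2ccc(-c3cccc(C(C)=O)c3)cc2)C(C)C)c1`, also gives a limit: > 26000 nM.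

Compound 3 therefore stands where the other two stand, at the limit of > 26000 nM in this assay, at which 3 of the 3 values shown sit; nothing about its own number is known beyond this. The unmeasured compound 4, `CCOC(=O)CCCCCOc1cccc(CN(C(=O)c2ccc(-c3ccc(Cl)c(Cl)c3)cc2)C(C)C)c1`, differs from compound 3 in one place: 3,4-dichlorophenyl in place of 3-acetylphenyl on an aromatic carbon. Two measured steps exist, but neither bears directly on this change: a step that the two limits leave unreadable from compound 1 to compound 2 and a step that the two limits leave unreadable from compound 1 to compound 3. Both run between values at the limit, so their sizes cannot be read, and neither exchanges 3-acetylphenyl for 3,4-dichlorophenyl. Going by the values given here, there is thus no measured step that sets a size for this change in this assay, and no direction can be read from the data. With all three measured compounds at the limit, compound 4 is expected to remain there too, an expected step that the limit leaves unreadable from compound 3 to compound 4, which is to say none that can be seen. In this assay compound 4 is estimated at 30000 nM, with an expected range from 10000 nM to 100000 nM, most likely reported as a limit again.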

Compound 4, half-maximal effective concentration: > 26000 nM
Compound 4: only a limit was reported; the forecaster's own chance of this, stated with the estimate: 80%; the middle value does not contradict the limit.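

In this assay compound 4 gives only a limit of the assay, > 26000 nM. Compound 3 also gives only a limit, so no step can be read for 3,4-dichlorophenyl in place of 3-acetylphenyl between compound 3 and compound 4. How much of any compound shown is needed for the effect stays open, as does whether any of these changes alters it, with every value at one place: the limit of > 26000 nM in this assay, at which 4 of the 4 values shown sit.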